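This account rests on a few compounds, and the source may have more. Where it says the series, first, only, none or still open, it means among the compounds named here.

Compound 1 `COc1nc(=O)ccn1[C@@H]1O[C@H](COP(=O)(O)O)[C@@H](O)[C@H]1O` is one of three nucleotides examined in an in vitro functional assay on 1321-N1 cells for agonist activity at P2Y purinoceptor 4 (Homo sapiens), read by scintillation proximity assay and inositol phosphate accumulation; on this read-out lower numbers stand for an effect already at smaller amounts and higher numbers for an effect only at larger amounts of compound. In this assay compound 1 gives only a limit, > 100000 nM. Compound 2 `O=c1[nH]c(=S)ccn1[C@@H]1O[C@H](COP(=O)(O)O)[C@@H](O)[C@H]1O` is likewise reported in this assay as a limit, > 100000 nM. Compound 3 `Nc1nc(=O)ccn1[C@@H]1O[C@H](COP(=O)(O)OP(=O)(O)O)[C@@H](O)[C@H]1O` also reaches no more than a limit in this assay, >= 100000 nM. Among the measured compounds shown here, compound 1 therefore stands exactly where every measured compound stands, at a limit rather than a number, as the limit of > 100000 nM in this assay, at which 2 of the 3 values shown sit, and the limit of >= 100000 nM in this assay, at which 1 of the 3 values shown sits, show, and no step between two measured compounds can be sized from these data.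

Compound 4 `CCCSc1nc(=O)ccn1[C@@H]1O[C@H](COP(=O)(O)O)[C@@H](O)[C@H]1O` differs from compound 1 in one place: propylsulfanyl in place of methoxy on an aromatic carbon. Because compound 1 gives > 100000 nM in this assay, there is no measured number from which a shift could be followed. For compound 4 the step from compound 1 is expected to stay within the scatter, a number no higher from compound 1 to compound 4 (the limit leaves the size open), in this assay. Compound 4 is accordingly estimated at 100000 nM, within 30000 nM to 300000 nM, with a limit rather than a number the likelier report.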

Compound 4, half-maximal effective concentration: > 100000 nM
Compound 4: no number, only a limit; the forecaster's own chance of this, stated with the estimate: 75%; the middle value lies on the limit itself.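

Compound 1 and compound 4 are both reported only as limits, so the step between them cannot be read. The compounds shown leave open whether any change on the shared core would give a measured number rather than a limit in this assay.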